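Cytotoxicity notes on an ester-chain aromatic series

This account rests on a few compounds, and the source may have more. Where it says the series, first, only, none or still open, it means among the compounds named here.

Compound 1, `CCCNCc1ccccc1OCCCCCC(=O)OCC`. In an ADME assay on HepG2 cells (Homo sapiens) for cytotoxicity, read by CellTiter-Glo and resazurin assay, with a stated time of 72 h (a higher number here means that more compound is needed for the effect, a lower number that less compound is needed), compound 1 gives > 26000 nM, which is a limit of the assay and not a number.
Compound 2, `CCCNCc1ccc(OCCCCCC(=O)OCC)cc1`. In this assay compound 2 gives > 26000 nM, again a limit of the assay.
Compound 3, `CCOC(=O)CCCCCOc1ccccc1C=O`. In this assay compound 3 gives > 26000 nM, also a limit of the assay.

Going by the values given here, all three measured values sit at the limit of > 26000 nM in this assay, at which 3 of the 3 values shown sit, so no compound can be ordered against another. The change from compound 1 to compound 3 is formyl in place of (propylamino)methyl on an aromatic carbon; in this assay it gives a step that the two limits leave unreadable from compound 1 to compound 3, as both ends are limits.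

Compound 4, `CCOC(=O)CCCCCOc1ccc(C=O)cc1`, is not yet measured. It stands to compound 2 as compound 3 stands to compound 1: the change is formyl in place of (propylamino)methyl on an aromatic carbon. The two changes are the same kind of change but not the same, since in compound 1 the group sits ortho to a large group and in compound 2 it sits para to a large group. The difference between the two cores of compound 1 and compound 2 is not broken down here.

In this assay the step from compound 2 to compound 4 is expected to be a step that the limit leaves unreadable from compound 2 to compound 4, resting on compound 1 and compound 3 both sitting at the limit of > 26000 nM in this assay, at which 3 of the 3 values shown sit. Compound 4 is therefore estimated at 32000 nM in this assay, most likely reported again as a limit.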

Compound 4, half-maximal effective concentration: > 26000 nM
Compound 4: no number, only a limit (the forecaster's own chance of this, stated with the estimate: 85%); the middle value is on the limit's open side.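

In this assay compound 4 gives > 26000 nM, a limit of the assay and not a number. No step can be read from compound 2 to compound 4, because both ends are limits: the limit of > 26000 nM in this assay, at which 4 of the 4 values shown sit. The compounds shown leave open whether formyl in place of (propylamino)methyl, or the difference between the cores of compound 1 and compound 2, changes the read-out in this assay at all.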